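The compounds below may be only part of what the source reports. "The series", "measured", "known", "first", "only" and "open" are said of these compounds alone.

Within the data shown here, only two compounds with this core have been tested so far in a functional assay on HepG2 cells (Homo sapiens) for antiproliferative activity, read by MTT assay, with a stated time of 24 h; on this read-out higher numbers stand for weaker inhibition and lower numbers for stronger inhibition. Compound 1 `COc1ccc(/C=C/C(=O)c2ccc(OC)c3c2OC(C)(C)C=C3)cn1` gives > 10000 nM, which is a limit of the assay and not a number. Compound 2 `COc1ccc(C(=O)/C=C/c2cccs2)c2c1C=CC(C)(C)O2` gives > 10000 nM, which is also a limit. Compound 2 therefore has no exact place on the scale, and the picture so far is the limit of > 10000 nM in this assay, at which 2 of the 2 values shown sit. Among the measured compounds shown here, the only measured step is a step that the two limits leave unreadable from compound 1 to compound 2, so it offers no size to carry forward.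

Compound 3 `COc1ccc(C(=O)/C=C/c2ccccc2Cl)c2c1C=CC(C)(C)O2` has 2-chlorophenyl in place of thiophen-2-yl on a double-bonded chain carbon bound to a double-bonded chain carbon, a change counted as 2-chlorophenyl in place of thiophen-2-yl on a double-bonded chain carbon bound to a double-bonded chain carbon. With no readable step to go on, no shift beyond the usual scatter can be predicted in this assay, and no direction can be favoured. The expected change is a step that the limit leaves unreadable from compound 2 to compound 3, an estimate that rests on the limit of compound 2 alone. For compound 3 the estimated value is 12000 nM, with an expected range of 4000 nM to 30000 nM, and a further limit is the likeliest report.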

Compound 3, half-maximal inhibitory concentration: > 10000 nM
Compound 3: only a limit was reported (the forecaster's own chance of this, stated with the estimate: 75%); the middle value lies beyond the limit too.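

Compound 1, compound 2 and compound 3 each gave only a limit in this assay, not a number, so the steps among them cannot be read and no size can be taken from them. The compounds shown leave open whether any group at this place on the shared core would give an exact value: the limit of > 10000 nM in this assay, at which 3 of the 3 values shown sit.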